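Adding one methyl to a compound at the assay limit

The source may hold more compounds than are shown below. What is called first, only, known or untested is meant among the compounds shown, and "the series" means these compounds.

Measured compounds:
compound 1 `Cc1ccc(-c2nc3ccccn3c2Sc2ccccc2)cc1`: > 100000 nM
compound 2 `COc1ccc(-c2nc3ccccn3c2Sc2ccccc2)cc1`: 91700 nM
compound 3 `C(=C/c1nc2ccccn2c1Sc1ccccc1)\c1ccccc1`: > 100000 nM

All three values come from an ADME assay on NIH3T3 cells (Mus musculus) for inhibition, read by MTT assay, with a stated time of 48 h; on this read-out higher numbers stand for weaker inhibition and lower numbers for stronger inhibition. Compound 1 gives > 100000 nM, which is a limit and not a number. Compound 3 gives > 100000 nM, also a limit. This is the limit of > 100000 nM in this assay, at which 2 of the 3 values shown sit, so compound 1 has no exact position on the scale.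

Compound 4 `Cc1ccc(-c2nc3ccc(C)cn3c2Sc2ccccc2)cc1` differs from compound 1 by methyl in place of hydrogen on an aromatic carbon. For the measured compounds named here, no measured step makes this change, so the evidence is indirect. Methoxy in place of methyl gave an at least 1.0-fold lower number from compound 1 to compound 2 (0.03 log units; that floor lies within the scatter). Replacing the 4-methoxyphenyl with 2-phenylethenyl gave an at least 1.0-fold higher number from compound 2 to compound 3 (0.03 log units; that floor lies within the scatter). The remaining comparison is a step that the two limits leave unreadable from compound 1 to compound 3. With only these steps to go on, no step beyond the scatter is expected in this assay, and no direction can be favoured.

Compound 4 is expected near 100000 nM, with an estimated range of 50000 nM to 200000 nM. This expected value means a number no higher from compound 1 to compound 4 (the limit leaves the size open).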

Compound 4, half-maximal inhibitory concentration: > 100000 nM
Compound 4: only a limit was reported; the forecaster's own chance of this, stated with the estimate: 65%; the middle value lies on the limit itself.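

In this assay compound 4 gives > 100000 nM, which is a limit and not a number. Compound 1 also sits at a limit, so no step can be read between compound 1 and compound 4: the limit of > 100000 nM in this assay, at which 3 of the 4 values shown sit.

On these data alone, whether the added methyl changes the read-out at all, and in which direction, stays open.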